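Amide ring variation at the side chain: compound 3 pending

The source may report more compounds than this note shows. Statements on the series, on what has been measured and on what is new or still open speak of the compounds shown alone.

compound 1 `CCCCCCCCN(C)C(=O)Cn1cc(Cc2cnc(=O)n(C)c2)c(=O)nc1SCc1ccc(F)cc1` — 19%
compound 2 `CCCCCCCCN(C)C(=O)Cn1cc(Cc2cnc(=O)n(CC(=O)N3CCOCC3)c2)c(=O)nc1SCc1ccc(F)cc1` — 36%

In a functional assay on a cell-free system (plasma, Oryctolagus cuniculus) for inhibition of platelet-activating factor acetylhydrolase (Homo sapiens), tested at 100 nM (on this read-out lower numbers stand for less inhibition and higher numbers for more inhibition at the one concentration tested (going by the name of the read-out)), compound 1 gives 19%, and compound 2 gives 36%. Compound 2 stands highest of the two numbers; the nearest is compound 1, and the step of a number 17 percentage points higher from compound 1 to compound 2 (beyond the scatter) is beyond the scatter, a modest rise for (morpholin-4-yl)carbonyl in place of hydrogen on a saturated chain carbon bound to an aromatic nitrogen.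

Compound 3 `CCCCCCCCN(C)C(=O)Cn1cc(Cc2cnc(=O)n(CC(=O)N3CCN(C(C)=O)CC3)c2)c(=O)nc1SCc1ccc(F)cc1` differs from compound 2 by 4-acetylpiperazin-1-yl in place of morpholin-4-yl on a carbonyl carbon. Among the compounds with values here, the one measured step, from compound 1 to compound 2, touches the same side chain, yet it adds the (morpholin-4-yl)carbonyl group outright rather than exchanging one six-membered non-aromatic ring with two hetero atoms for another on the carbonyl carbon. Within the data shown here, no measured step bears directly on that exchange, so in this assay no step beyond the scatter is expected for compound 3; the expected step is no change at the digits printed from compound 2 to compound 3 (within the scatter). Compound 3 is therefore estimated at 36%, with a range from 18% to 54%.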

Compound 3, a percentage reported as inhibition, at one concentration (the size of the read-out at that concentration, not a potency): 49%
Compound 3: middle estimate off by 13 percentage points, on the low side, and the stated range covers the measured number.
By their numbers in this assay, from the lowest: compound 1; then compound 2; then compound 3.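

In this assay, 4-acetylpiperazin-1-yl in place of morpholin-4-yl on a carbonyl carbon gives a number 13 percentage points higher from compound 2 to compound 3 (beyond the scatter), so the read-out responds to the ring at the end of the side chain and not only to the addition of the side chain as a whole. Against the parent with hydrogen on the saturated chain carbon bound to an aromatic nitrogen, (4-acetylpiperazin-1-yl)carbonyl gives a number 30 percentage points higher from compound 1 to compound 3 (beyond the scatter), which puts compound 3 at the top of these three, with its steps to both others printed as beyond the scatter. Nothing measured in this series speaks to why the exchange of rings goes with a higher number.

Which part of the entering group goes with the step remains open: an unsubstituted piperazin-1-yl with its free amine, or 4-methylpiperazin-1-yl, on the same carbonyl carbon would separate the acetyl group from the second ring nitrogen. The numbers also come from one concentration only, so they rank these compounds by inhibition at that concentration and leave their potencies open.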